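The compounds below may be only part of what the source reports. "The series", "measured", "known", "first", "only" and "open" are said of these compounds alone.

Compound 1: `CNc1ncc2c(-c3ccc(N4CCNCC4)nc3)nn(CC3CCCC3)c2n1`
Compound 2: `CNc1ncc2c(-c3ccc(N4CCN(C)CC4)nc3)nn(Cc3cn(Cc4ccccc4)nn3)c2n1`

In an assay for inhibition of tyrosine-protein kinase receptor TYRO3 (Homo sapiens), read by 33P incorporation, in the presence of a further agent that is not named here (on this read-out lower numbers stand for stronger inhibition and higher numbers for weaker inhibition), compound 1 gives > 10000 nM. In this assay compound 2 gives > 10000 nM. Each of these readings is a limit of the assay rather than a number: the limit of > 10000 nM in this assay, at which 2 of the 2 values shown sit. Compound 2 therefore stands at that limit, as does compound 1. Compound 3 `CNc1ncc2c(-c3ccc(N4CCN(C)CC4)nc3)nn(CC3CCCC3)c2n1` differs from compound 2 by cyclopentyl in place of 1-benzyl-1H-1,2,3-triazol-4-yl on a saturated chain carbon bound to an aromatic nitrogen. Among the compounds with values here, no measured step covers this change, and compound 1, which also carries cyclopentyl on that carbon, sits at the same limit, so nothing here points to a gain. The step that the limit leaves unreadable from compound 2 to compound 3 is expected to be none beyond the scatter. For compound 3 the estimate in this assay is 15000 nM, with a range from 3000 nM to 60000 nM.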

Compound 3, half-maximal inhibitory concentration: 3670 nM
Estimate against measurement, compound 3: 4.1-fold (0.61 log units) above; low and high end bracket the measured number.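

In this assay, methyl in place of hydrogen on an amine nitrogen in a ring gives an at least 2.7-fold lower number from compound 1 to compound 3 (0.43 log units; beyond the scatter), so this nitrogen matters when cyclopentyl is present. Cyclopentyl in place of 1-benzyl-1H-1,2,3-triazol-4-yl on a saturated chain carbon bound to an aromatic nitrogen gives an at least 2.7-fold lower number from compound 2 to compound 3 (0.43 log units; beyond the scatter), so of these two groups, cyclopentyl gives the stronger inhibition. Both sizes are only minimums because compound 1 and compound 2 each sit at a limit: the limit of > 10000 nM in this assay, at which 2 of the 3 values shown sit.

As far as these compounds go, whether ethyl on that amine nitrogen, or cyclohexyl or phenyl on that chain carbon, would lower the number further remains open.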